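The source may hold more compounds than are shown below. What is called first, only, known or untested is meant among the compounds shown, and "the series" means these compounds.

In an ADME assay on the whole organism (Mus musculus, strain BALB/c) for pharmacokinetics, read by LC-MS, with a stated time of 600 min, at a dose of 20 mg/kg by the oral route (a lower number here means less compound in the circulation, a higher number more compound in the circulation at the dose given), two compounds have been measured so far:

Compound 1 `CN(CCCNC(=O)Nc1ccc(C(C)(C)C)cc1)C[C@H]1C[C@@H](c2ccc3c(N)ncnn23)[C@H](O)[C@@H]1O`: 8.53 ng.h/mL
Compound 2 `CC(C)NC[C@@H]1C[C@H](c2ccc3c(N)ncnn23)[C@@H](O)[C@H]1O`: 845 ng.h/mL

Compound 2 stands higher of the two, and its gap to compound 1 lies beyond the scatter. Compound 3 `CC(C)NC[C@H]1C[C@@H](c2ccc3c(N)ncnn23)[C@H](O)[C@@H]1O` relates to it as follows: the two compounds have the same atoms and bonds and differ only in configuration as drawn: 4 of 4 stereo elements differ (all stereocentres are inverted: mirror images); a stereocentre at a saturated ring carbon is drawn S in compound 2 and R in compound 3; a stereocentre at a saturated ring carbon is drawn R in compound 2 and S in compound 3; a stereocentre at a saturated ring carbon is drawn R in compound 2 and S in compound 3; a stereocentre at a saturated ring carbon is drawn S in compound 2 and R in compound 3. Within the data shown here, no measured pair shows what such an inversion does in this assay, so no direction can be expected and the range stays wide. Only a small change, within the scatter, is expected. The estimated change is a 1.2-fold lower number from compound 2 to compound 3 (0.08 log units; within the scatter). Compound 3 is expected at about 700 ng.h/mL, with an estimated range of 250 ng.h/mL to 2000 ng.h/mL.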

Compound 3, area under the concentration-time curve: 1300 ng.h/mL
The estimate for compound 3 lay 1.9-fold (0.27 log units) below the measured number; measured number inside the range.
By their numbers in this assay, from the lowest: compound 1; then compounds 2 and 3 (each within the scatter of the next).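

Among these compounds, this is the first pair in which only configuration changes, with all four stereocentres inverted, and in this assay the inversion gives a 1.5-fold higher number from compound 2 to compound 3 (0.19 log units; within the scatter). The mirror image therefore shows no difference in exposure that stands clear of the usual scatter. This step can be read as a test of configuration alone: the fact that compounds 2 and 3 differ only in the configuration as drawn

Going by these compounds, whether inverting only some of the stereocentres would leave the number as little moved stays open. So does whether the mirror images would also stay close with a cyclopropyl group in place of the isopropyl group.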